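Amine variation on the shared core: compound 3 to compound 4

A few compounds are considered here, and "the series" means these few. Any claim that something is new, unique, unknown or untested is made for them only; others in the source may bear on it.

Compound 3 `CCCCNC(C)c1cc2c(cc1OC)OC(C)(C)C=C2` gives 22 nM in an assay on cell membranes for displacement of a labelled ligand from Sigma non-opioid intracellular receptor 1 (Cavia porcellus), read by scintillation counting (a lower number here means a stronger inhibitor, a higher number a weaker inhibitor), the lowest of the three numbers shown. Compound 2 `CCNC(C)c1cc2c(cc1OC)OC(C)(C)C=C2` gives 83 nM and compound 1 `COc1cc2c(cc1C(C)N[C@@H](C)c1ccccc1)C=CC(C)(C)O2` gives 805 nM; the steps of a 3.8-fold lower number from compound 2 to compound 3 (0.58 log units; beyond the scatter) and a 37-fold lower number from compound 1 to compound 3 (1.56 log units; beyond the scatter) both lie beyond the scatter, as does a 9.7-fold lower number from compound 1 to compound 2 (0.99 log units; beyond the scatter). Compound 4 `COc1cc2c(cc1C(C)N1CCCC1)C=CC(C)(C)O2` differs from compound 3 by pyrrolidin-1-yl in place of butylamino on a saturated chain carbon bound to an aromatic carbon and a saturated chain carbon. Within the data shown here, no measured step closes the amine substituent into a ring, so the nearest guides are a 3.8-fold lower number from compound 2 to compound 3 (0.58 log units; beyond the scatter) and a 37-fold lower number from compound 1 to compound 3 (1.56 log units; beyond the scatter), which show the amine substituent matters, with the five-heavy-atom butylamino giving the lowest number. Compound 4 is expected to stay close to compound 3, a step of a 1.1-fold higher number from compound 3 to compound 4 (0.06 log units; within the scatter) in this assay, within or near the scatter. The estimate for compound 4 is 25 nM, range 8 nM to 80 nM.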

Compound 4, inhibition constant: 19 nM
Estimate against measurement, compound 4: 1.3-fold (0.12 log units) above; measured number inside the range.
By their numbers in this assay, from the lowest: compounds 4 and 3 (each within the scatter of the next); then compound 2; then compound 1.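

Closing the amine substituent into a ring gives a 1.2-fold lower number from compound 3 to compound 4 (0.06 log units; within the scatter) in this assay, so at this position pyrrolidin-1-yl, with 0 hydrogen-bond donors, reads the same as open-chain butylamino, with 1. The ring also holds a clear difference from the shorter open chain, with a 4.4-fold lower number from compound 2 to compound 4 (0.64 log units; beyond the scatter). Nothing available explains either step.

Going by these compounds, whether a piperidin-1-yl or morpholin-4-yl ring would hold the number at this position remains open. So does the effect of a longer chain on the amine nitrogen, such as hexylamino.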